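A methoxy in place of fluoro: what compound 4 may give

The source may hold more compounds than are shown below. What is called first, only, known or untested is meant among the compounds shown, and "the series" means these compounds.

Of the compounds shown here, three sharing one core have been measured in an assay on isolated protein for inhibition of protein deacetylase HDAC6 (Homo sapiens); a higher number here means a weaker inhibitor, a lower number a stronger inhibitor. Compound 1 `O=C(NO)c1ccc(CN2C(=O)/C(=C3\Nc4ccccc4\C3=N/O)c3cc(Cl)ccc32)cc1` gives 16 nM, compound 2 `O=C(NO)c1ccc(CN2C(=O)/C(=C3\Nc4ccccc4\C3=N/O)c3cc(F)ccc32)cc1` gives 43 nM and compound 3 `O=C(NO)c1ccc(CN2C(=O)/C(=C3\Nc4ccccc4\C3=N/O)c3cccc(Cl)c32)cc1` gives 49 nM. Compound 2 thus stands second highest of the three numbers; compound 3 sits within the scatter of it, while compound 1 lies beyond the scatter below it. Among the measured compounds shown here, the one measured step between compounds that differ in a single place, a 2.7-fold higher number from compound 1 to compound 2 (0.43 log units; beyond the scatter), shows that exchanging one halogen for another on this aromatic carbon moves the number modestly.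

Compound 4 `COc1ccc2c(c1)/C(=C1/Nc3ccccc3/C1=N\O)C(=O)N2Cc1ccc(C(=O)NO)cc1` differs from compound 2 in methoxy in place of fluoro on an aromatic carbon. For the measured compounds named here, no measured step involves a methoxy, so the step from compound 1 to compound 2 is the only guide, and it shows that a change of the group on this aromatic carbon produces a modest shift. Compound 4 is therefore expected to lie within a modest step of compound 2 in this assay, in either direction. The estimated step is a 1.2-fold lower number from compound 2 to compound 4 (0.09 log units; within the scatter). Compound 4 is expected to give 35 nM, with a range from 12 nM to 100 nM.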

Compound 4, half-maximal inhibitory concentration: 30 nM
Compound 4: middle estimate off by 1.2-fold (0.07 log units), on the high side; the measured number falls inside the stated range.
By their numbers in this assay, from the lowest: compounds 1, 4, 2 and 3 (each within the scatter of the next, the first and the last beyond it).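

In this assay, the step of a 1.4-fold lower number from compound 2 to compound 4 (0.16 log units; within the scatter) and the step of a 1.9-fold higher number from compound 1 to compound 4 (0.27 log units; within the scatter) both lie within the scatter. Methoxy, the first group on this aromatic carbon that is not a halogen, therefore sits within the scatter of both compound 1 and compound 2, although those two are separated by a step beyond it. At this place, then, exchanging a single heavy atom for two, with one hydrogen-bond acceptor entering, gives a number that cannot be told apart from either halogen compound, and no evidence is available on the reason for this result.

The compounds shown leave open whether an amine, a carboxylic acid or a longer chain such as ethoxy on this carbon would stay within the same span. They also leave open how methoxy would behave on the carbon that carries chloro in compound 3.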